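The source may report more compounds than this note shows. Statements on the series, on what has been measured and on what is new or still open speak of the compounds shown alone.

Compound 2 `CN(Cc1ccc(OCCCNC(=N)N)cc1)c1nc2ccc(Oc3cccc(C(F)(F)F)c3)cc2s1` sits in a series of two measured compounds. In an assay on cells for inhibition of Voltage-dependent T-type calcium channel subunit alpha-1H (Homo sapiens), read by FLIPR and calcium flux, with stated times of 600 s and 300 s (on this read-out lower numbers stand for stronger inhibition and higher numbers for weaker inhibition), compound 2 gives 771000 nM, and compound 1 `CN(Cc1ccc(OCCCN)cc1)c1nc2ccc(Oc3ccc(F)cc3)cc2s1` gives 492000 nM in this assay, the two values lying within the scatter of each other. Compound 3 `CN(Cc1ccc(OCCCN)cc1)c1nc2ccc(Oc3cccc(C(F)(F)F)c3)cc2s1` differs from compound 2 by a hydrogen atom in place of a group of 3 heavy atoms (1 carbon, 2 nitrogen; no ring), on an amine nitrogen. Within the data shown here, no step of this kind has been measured here, so a step from compound 2 to compound 3 of no more than the scatter is expected, with a 1.4-fold lower number from compound 2 to compound 3 (0.15 log units; within the scatter). For compound 3 in this assay the expected value is 550000 nM, between 200000 nM and 1500000 nM.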

Compound 3, half-maximal inhibitory concentration: 239000 nM
Compound 3: the middle estimate sits 2.3-fold (0.36 log units) above what was measured; the range from low to high includes it.
By their numbers in this assay, from the lowest: compound 3; then compounds 1 and 2 (each within the scatter of the next).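

In this assay, a hydrogen atom in place of the group of 3 heavy atoms on the amine nitrogen gives a 3.2-fold lower number from compound 2 to compound 3 (0.51 log units; beyond the scatter), so this nitrogen's substituent changes the read-out by more than the scatter. With that amine kept, 3-(trifluoromethyl)phenyl in place of 4-fluorophenyl on an oxygen on an aromatic ring gives a 2.1-fold lower number from compound 1 to compound 3 (0.31 log units; beyond the scatter), so the aryl group matters too. Nothing available explains either step. The compounds shown leave open how an acetyl group on this nitrogen would read, and whether a carboxylic acid in place of the amine, or a longer chain carrying it, would move the number further.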